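The source may hold more compounds than are shown below. What is called first, only, known or untested is meant among the compounds shown, and "the series" means these compounds.

Working notes on the carbonate series. In an ADME assay on MRC5 cells (Homo sapiens) for inhibition, read by MTT assay, with a stated time of 72 h (a higher number here means a weaker inhibitor, a lower number a stronger inhibitor), compound 3 `CCCCOC(=O)OCCc1ccc(O)c(O)c1` stands at "not determined" (no result reported), so it has no number from which to measure a step. Compound 1 `O=C(OCCOC(=O)OCCc1ccc(OCc2ccccc2)c(OCc2ccccc2)c1)OCCc1ccc(OCc2ccccc2)c(OCc2ccccc2)c1` is in the same position, with "not determined" (no result reported). Compound 2 `O=C(OCCCCCCCCOC(=O)OCCc1ccc(O)c(O)c1)OCCc1ccc(O)c(O)c1` reads > 50000 nM, which is a limit of the assay and not a number. Going by the values given here, the only quantitative information is thus (the limit of > 50000 nM in this assay, at which 1 of the 3 values shown sits).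

The next compound is compound 4 `CCCCCCCCCOC(=O)OCCc1ccc(O)c(O)c1`. The change is pentyl in place of hydrogen on a saturated chain carbon, four bonds along the chain from an oxygen next to a carbonyl group. Cut one bond further out, the same difference reads methyl to hexyl.

Among the compounds with values here, no measured step shows what this change does, so the expected step is a judgement only. A modest move towards stronger inhibition is expected, not far beyond the usual scatter, leaving compound 4 a weak inhibitor in this assay. This expectation leans on compound 2 at > 50000 nM, and a reading reported only as a limit is quite likely for compound 4 too. In this assay the estimate for compound 4 is 30000 nM, with an expected range of 8000 nM to 60000 nM.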

Compound 4, half-maximal inhibitory concentration: 15900 nM
Beside the measured number, compound 4's estimate is 1.9-fold (0.28 log units) above it; low and high end bracket the measured number.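

No new step can be read from compound 4 in this assay: compound 3, which differs from it in one place, has no single number to set against it. The compounds shown leave open what pentyl in place of hydrogen on a saturated chain carbon does to inhibition in this assay.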